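A Nucleobase Swap in a Weakly Inhibiting Lactone Series

The source may hold more compounds than are shown below. What is called first, only, known or untested is meant among the compounds shown, and "the series" means these compounds.

compound 1 `O=C1O/C(=C\Cn2ccc(NC(=O)c3ccccc3)nc2=O)C(OCc2ccccc2)=C1OCc1ccccc1`: 8490 nM
compound 2 `NC1(CCn2ncc(=O)[nH]c2=O)OC(=O)C(OCc2ccccc2)=C1OCc1ccccc1`: > 100000 nM
compound 3 `Nc1ccn(C[C@H](O)[C@H]2OC(=O)C(OCc3ccccc3)=C2OCc2ccccc2)c(=O)n1`: 53900 nM

The three measured compounds share a common core and differ in the heterocycle attached through a short chain. In an ADME assay on WI-38 cells (Homo sapiens) for inhibition, read by MTT assay, with a stated time of 72 h (a higher number here means a weaker inhibitor, a lower number a stronger inhibitor), compound 1 gives 8490 nM. Compound 3 gives 53900 nM. For compound 2 the reading is a limit of the assay, > 100000 nM, and not a measured number. Compound 2 therefore stands at the limit of > 100000 nM in this assay, at which 1 of the 3 values shown sits, with no value of its own to anchor a step. No two of these compounds differ in one place only, so no single step is measured among them.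

Compound 4, `NC1(CCn2c(=O)[nH]c(=O)[nH]c2=O)OC(=O)C(OCc2ccccc2)=C1OCc1ccccc1`, is the untested partner of compound 2. The change is a group of 9 heavy atoms (3 carbon, 3 nitrogen, 3 oxygen; one six-membered aromatic ring with 3 hetero atoms) in place of a group of 8 heavy atoms (3 carbon, 3 nitrogen, 2 oxygen; one six-membered aromatic ring with 3 hetero atoms), on a saturated chain carbon, two bonds along the chain from a saturated ring carbon. Since compound 2 gives only a limit, the step cannot be read from a starting number. Nothing in the shown data points to a move beyond the scatter in either direction; the most likely outcome is again a reading at the limit. Compound 4 is estimated at 130000 nM, with a range from 40000 nM to 400000 nM. This estimate means an expected step that the limit leaves unreadable from compound 2 to compound 4, within the scatter, with a real chance that only a limit is reported once more.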

Compound 4, half-maximal inhibitory concentration: > 100000 nM
Compound 4 ended at the assay's limit (the forecaster's own chance of this, stated with the estimate: 70%); the middle value lies beyond the limit too.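

In this assay compound 4 gives > 100000 nM, a limit of the assay and not a number. Compound 2 also sits at a limit, so no step between compound 2 and compound 4 can be read: the limit of > 100000 nM in this assay, at which 2 of the 4 values shown sit.

Still open, on these data alone, is whether this ring change alters inhibition at all, in compounds whose readings are measured numbers.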